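Stability of a Double Ester: From Compound 1 to Compound 3

The source may hold more compounds than are shown below. What is called first, only, known or untested is meant among the compounds shown, and "the series" means these compounds.

Compound 1 `CCC(CC)C(=O)OCOC(=O)C1=C(S[C@@H]2CN[C@H](C(=O)Nc3cccc(C(=O)O)c3)C2)[C@H](C)[C@@H]2[C@@H]([C@@H](C)O)C(=O)N12`: > 95%
Compound 2 `CC(C)OC(=O)C1=C(S[C@@H]2CN[C@H](C(=O)Nc3cccc(C(=O)O)c3)C2)[C@H](C)[C@@H]2[C@@H]([C@@H](C)O)C(=O)N12`: > 95%

In an ADME assay for metabolic stability, read by LC-MS, with a stated time of 3 h, at pH 6.5, tested at 50 uM (a lower number here means that less of the compound is left, a higher number that more of the compound is left), compound 1 gives > 95%, which is a limit of the assay and not a number. Compound 2 gives > 95% in this assay, again a limit. The step that the two limits leave unreadable from compound 1 to compound 2 is therefore not readable, since both ends rest on (the limit of > 95% in this assay, at which 2 of the 2 values shown sit). Going by the values given here, that is all the measured material: two readings at the same limit and no step of readable size.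

Compound 3 `CCC(CC)C(=O)OCOC(=O)C1=C(S[C@@H]2CN[C@H](C(=O)Nc3cccc(C(=O)OCOC(=O)C(CC)CC)c3)C2)[C@H](C)[C@@H]2[C@@H]([C@@H](C)O)C(=O)N12` differs from compound 1 by (((pentan-3-yl)carbonyl)oxy)methyl in place of hydrogen on an oxygen next to a carbonyl group. Among the compounds with values here, no measured step bears on this change, as the only step between measured compounds, from compound 1 to compound 2, has no readable size. With compound 1 standing at > 95% and nothing pointing downward, the author expects compound 3 to stay high in this assay, with some allowance for a compound carrying two such ester groups. The author estimates compound 3 at 90%, between 75% and 98%. The expected step is a number at least 5 percentage points lower from compound 1 to compound 3 (that floor lies within the scatter).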

Compound 3, percent of the compound remaining: > 95%
Compound 3 gave a limit, no number (the forecaster's own chance of this, stated with the estimate: 50%); middle value at least 5 percentage points away from the limit.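

In this assay, going by these compounds alone, compound 3 gives > 95%, which is a limit of the assay and not a number, so no step from compound 1 to compound 3 can be read: the limit of > 95% in this assay, at which 3 of the 3 values shown sit. The compounds shown leave open whether (((pentan-3-yl)carbonyl)oxy)methyl in place of hydrogen changes the reading in this assay at all.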